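An ethoxy analogue of two closely matched compounds

The source may hold more compounds than are shown below. What is called first, only, known or untested is meant among the compounds shown, and "the series" means these compounds.

Measured in a functional assay on J774.A1 cells (Mus musculus) for inhibition, read by Griess assay, with stated times of 1 h and 24 h; a lower number here means a stronger inhibitor, a higher number a weaker inhibitor:
- compound 1 `CC(C)CCOc1ccccc1C1CC(=O)c2ccccc2O1`: 42600 nM
- compound 2 `COCOc1ccccc1C1CC(=O)c2ccccc2O1`: 35200 nM

In this assay, compound 2 gives 35200 nM, which cannot be separated from the other measured compound. Within the data shown here, the only measured step is a 1.2-fold lower number from compound 1 to compound 2 (0.08 log units; within the scatter), so the two compounds stand level within the scatter.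

Compound 3 `CCOc1ccccc1C1CC(=O)c2ccccc2O1` has not yet been measured. It differs from compound 2 in one place: methyl in place of methoxy on a saturated chain carbon bound to an oxygen on an aromatic ring. This puts methyl in place of methoxy on a saturated chain carbon bound to an oxygen on an aromatic ring, so methoxymethoxy becomes ethoxy.

Among the measured compounds shown here, the one measured step bears on this change since it falls at the same place on the chain. There, methoxy in place of isobutyl gave only a 1.2-fold lower number from compound 1 to compound 2 (0.08 log units; within the scatter). For the measured compounds named here, no measured pair carries this exact change, so the evidence is thin, and no step beyond the scatter is expected in this assay. The estimated step is a 1.1-fold higher number from compound 2 to compound 3 (0.03 log units; within the scatter). Compound 3 is expected to give about 38000 nM, with an estimated range of 20000 nM to 70000 nM.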

Compound 3, half-maximal inhibitory concentration: 38800 nM
Compound 3: middle estimate off by 1.0-fold (0.01 log units), on the low side; the range from low to high includes it.
By their numbers in this assay, from the lowest: compounds 2, 3 and 1 (each within the scatter of the next).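

In this assay, methyl in place of methoxy on a saturated chain carbon bound to an oxygen on an aromatic ring gives a 1.1-fold higher number from compound 2 to compound 3 (0.04 log units; within the scatter), so methoxymethoxy and ethoxy cannot be told apart here, even though one hydrogen-bond acceptor leaves with the methoxy. The change further out, hydrogen in place of isopropyl on a saturated chain carbon, two bonds along the chain from an oxygen on an aromatic ring, gives a 1.1-fold lower number from compound 1 to compound 3 (0.04 log units; within the scatter), so this second position also shows no step beyond the scatter, and all three compounds stand level. Nothing available gives a measured reason for this flat reading at either place on the chain.

All three chains are neutral and end in plain alkyl groups, which leaves open whether an amine or a carboxylic acid at the end of the chain would produce a step beyond the scatter. Since the shared core is the same throughout, the compounds also leave open whether a change there, such as a fluorine on one of its aromatic rings, would shift the number at all.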